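Capping the acid side chain of compound 3

The source may report more compounds than this note shows. Statements on the series, on what has been measured and on what is new or still open speak of the compounds shown alone.

Compound 1 `Cn1ncc(Cl)c1-c1cc(C(=O)N[C@@H]2CNCC[C@H]2c2ccc(C(F)(F)F)cc2)oc1Cl` gives 120 nM in a functional assay on OVCAR-8 cells (Homo sapiens) for antiproliferative activity; on this read-out lower numbers stand for stronger inhibition and higher numbers for weaker inhibition. Compound 2 `O=C(N[C@@H]1CNCC[C@H]1c1ccc(Cl)cc1)c1ccc(-c2ncnc3c2CCC3O)s1` gives 24100 nM. Compound 3 `Cn1ncc(Cl)c1-c1cc(C(=O)N[C@@H]2CN[C@H](CC(=O)O)C[C@H]2c2ccc(Cl)c(Cl)c2)oc1Cl` gives 5120 nM.

Among these three numbers compound 3 stands second highest: compound 2 sits higher and compound 1 far lower, both separations lying beyond the scatter. Compound 4 `Cn1ncc(Cl)c1-c1cc(C(=O)N[C@@H]2CN[C@H](CC(=O)NCCO)C[C@H]2c2ccc(Cl)c(Cl)c2)oc1Cl` has not yet been measured. It differs from compound 3 in one place: (2-hydroxyethyl)amino in place of hydroxy on a carbonyl carbon. Among the measured compounds shown here, no measured pair shows this same change, so its effect has to be guessed. The carboxy group of compound 3 is the sole feature setting it apart from the far more potent compound 1 beyond the aryl substitution, and replacing the hydroxy with (2-hydroxyethyl)amino is expected to move the number modestly downward, beyond the scatter, as a 3.4-fold lower number from compound 3 to compound 4 (0.53 log units; beyond the scatter). Compound 4 is therefore expected to reach about 1500 nM, within 400 nM to 6000 nM.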

Compound 4, half-maximal inhibitory concentration: 1450 nM
Estimate against measurement, compound 4: 1.0-fold (0.01 log units) above; low and high end bracket the measured number.
By their numbers in this assay, from the lowest: compound 1; then compound 4; then compound 3; then compound 2.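

In this assay, (2-hydroxyethyl)amino in place of hydroxy on a carbonyl carbon gives a 3.5-fold lower number from compound 3 to compound 4 (0.55 log units; beyond the scatter). Among the compounds shown here, this is the first reading of any change at this place, and it shows that the carboxy group of compound 3 can be converted to the (2-hydroxyethyl)carbamoyl group of compound 4 with a gain rather than a loss on this read-out. Nothing available here explains the step.

The compounds shown leave open whether a primary amide, a methyl amide or a longer chain ending in an amine would take the number lower. They also leave open whether removing the whole carboxymethyl side chain would do so.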